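Taking the chloro group off compound 2

The compounds below may be only part of what the source reports. "The series", "measured", "known", "first", "only" and "open" are said of these compounds alone.

Of the compounds shown here, two have numbers so far. In a functional assay on the whole organism for antagonist activity, with Mus musculus as the target (a lower number here means that less compound is needed, a higher number that more compound is needed for the effect), compound 1 `CNCC(=O)NCC(=O)N(C)c1ccc(Cl)cc1C(=O)c1ccccc1Cl` gives 1.55 mg/kg and compound 2 `CN(C(=O)CNC(=O)CN)c1ccc([N+](=O)[O-])cc1C(=O)c1ccccc1Cl` gives 0.32 mg/kg. Compound 2 holds the lower of the two numbers, with a gap beyond the scatter. These two compounds differ in more than one place, so the gap isolates no single group.

Compound 3 `CN(C(=O)CNC(=O)CN)c1ccc([N+](=O)[O-])cc1C(=O)c1ccccc1` has hydrogen in place of chloro on an aromatic carbon, ortho to a large group (hydrogen in place of chloro on an aromatic carbon). This turns 2-chlorophenyl into phenyl. Among the compounds with values here, both measured compounds carry the 2-chlorophenyl, and no measured pair shows this change alone, so the expectation is a judgement. The expected step in this assay is a 3.8-fold higher number from compound 2 to compound 3 (0.57 log units; beyond the scatter), towards a higher number and beyond the scatter. For compound 3 the estimated value is 1.2 mg/kg, with an expected range from 0.4 mg/kg to 3.6 mg/kg.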

Compound 3, dose for half-maximal effect: 0.28 mg/kg
For compound 3 the middle estimate is 4.3-fold (0.63 log units) above the measured one, and the stated range ends above it.
By their numbers in this assay, from the lowest: compounds 3 and 2 (each within the scatter of the next); then compound 1.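

In this assay, hydrogen in place of chloro on an aromatic carbon, ortho to a large group, gives a 1.1-fold lower number from compound 2 to compound 3 (0.06 log units; within the scatter). Within the data shown here, this is the first pair that differs in one place only, and at this place 2-chlorophenyl and phenyl cannot be told apart, so the low number of compound 2 does not depend on its chloro group. No measurement on hand bears on why this change leaves the number in place.

Open, from the compounds shown here alone, is whether a fluoro, methoxy or trifluoromethyl group on the same aromatic carbon would move the number in this assay. Also open, going by these compounds, is whether the chloro-to-hydrogen change reads the same where the nitro group gives way to the other chloro group of compound 1.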